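The source may hold more compounds than are shown below. What is called first, only, known or untested is meant among the compounds shown, and "the series" means these compounds.

Measured so far:
- compound 1, `O=C(Nc1cccc(-n2cc(-c3ccncc3)c(-c3ccc(Cl)c(O)c3)n2)c1)Nc1ccc(Cl)c(Cl)c1`, gives 1180 nM
- compound 2, `COc1cc(-c2nn(-c3cccc(NC(=O)Nc4ccc(Cl)c(C(F)(F)F)c4)c3)cc2-c2ccncc2)ccc1Cl`, gives 1080 nM

In a functional assay on M14 cells (Homo sapiens) for inhibition, read by sulforhodamine B assay, with a stated time of 48 h (a higher number here means a weaker inhibitor of growth, a lower number a stronger inhibitor of growth), compound 2 stands with the lowest of the two numbers, but its nearest neighbour compound 1 sits within the scatter of it, so the two values show no difference that can be read as an order. Within the data shown here, compound 1 and compound 2 differ in two places at once, so their pair gives no clean step; their values merely show that a hydroxy and a methoxy on the shared core both land in the same region of this assay.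

Compound 3, `O=C(Nc1cccc(-n2cc(-c3ccncc3)c(-c3ccc(Cl)c(O)c3)n2)c1)Nc1ccc(Cl)c(C(F)(F)F)c1`, is not yet measured. It differs from compound 2 by hydrogen in place of methyl on an oxygen on an aromatic ring; the urea part of compound 2 is kept.

Among the measured compounds shown here, no measured step of this kind exists. Given that compound 1, which carries the hydroxy, gives 1180 nM, no step beyond the scatter is expected in this assay, in either direction; the estimated step from compound 2 to compound 3 is a 1.1-fold higher number from compound 2 to compound 3 (0.05 log units; within the scatter). Compound 3 is therefore expected at 1200 nM, with a range from 500 nM to 2900 nM.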

Compound 3, concentration for 50% growth inhibition: 886 nM
Compound 3: middle estimate off by 1.4-fold (0.13 log units), on the high side; measured number inside the range.
By their numbers in this assay, from the lowest: compounds 3, 2 and 1 (each within the scatter of the next).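

In this assay the methoxy to hydroxy change on the 4-chloro-3-methoxyphenyl group now has a clean reading of a 1.2-fold lower number from compound 2 to compound 3 (0.09 log units; within the scatter) with the urea part kept, so hydrogen and methyl on this oxygen on an aromatic ring cannot be told apart here. The urea part also has its first clean reading: with the 4-chloro-3-hydroxyphenyl group kept, trifluoromethyl in place of chloro on an aromatic carbon gives a 1.3-fold lower number from compound 1 to compound 3 (0.12 log units; within the scatter) and thus no readable difference between these two groups. Nothing at hand offers a cause for either result.

The compounds shown cover only hydrogen and methyl on this oxygen, so it remains open whether a longer chain there, or an amine or a carboxylic acid in place of the hydroxy, would give a step beyond the scatter. From the compounds shown here alone, it is equally open whether a nitrile in place of the trifluoromethyl would leave the number in the same region.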